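A Fluorine on the Distal Phenyl Ring

A few compounds are considered here, and "the series" means these few. Any claim that something is new, unique, unknown or untested is made for them only; others in the source may bear on it.

Measured compounds:
compound 1, `COC(=O)c1sc2cc(C#Cc3cccc(N)c3)cnc2c1N`: 11600 nM
compound 2, `COC(=O)c1sc2cc(C#Cc3ccccc3)cnc2c1N`: > 150000 nM

Of the compounds shown here, two have so far been tested in a functional assay on A375-C5 cells (Homo sapiens) for inhibition, read by sulforhodamine B assay, with a stated time of 48 h; a lower number here means a stronger inhibitor of growth, a higher number a weaker inhibitor of growth. Compound 1 gives 11600 nM there. Compound 2 reaches only > 150000 nM, which is a limit of the assay and not a number. Compound 2 thus stands at the weaker end of the two values shown, and the step of an at least 12-fold higher number from compound 1 to compound 2 (1.11 log units; beyond the scatter) records that fall; its stated size rests on (the limit of > 150000 nM in this assay, at which 1 of the 2 values shown sits), where compound 2 sits.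

Compound 3, `COC(=O)c1sc2cc(C#Cc3ccc(F)cc3)cnc2c1N`, differs from compound 2 by fluoro in place of hydrogen on an aromatic carbon. Going by the values given here, no measured step concerns a fluoro entering this ring. Among the compounds with values here, the single step on record is the loss of the amino group, and it is large, but it says nothing about a fluoro on the other aromatic ring. With no evidence that this small change moves the number, compound 3 is expected to remain where compound 2 lies, so that a number no higher from compound 2 to compound 3 (the limit leaves the size open) is estimated to be no step beyond the scatter. Compound 3 is therefore expected at about 150000 nM in this assay, within a range of 40000 nM to 300000 nM, most likely again reported only as a limit.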

Compound 3, concentration for 50% growth inhibition: 48400 nM
Beside the measured number, compound 3's estimate is 3.1-fold (0.49 log units) above it, within the range that was stated.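

In this assay, a fluoro on the distal ring, para to a large group, brings a measurable gain over the bare phenyl ring: an at least 3.0-fold lower number from compound 2 to compound 3 (0.49 log units; beyond the scatter). So the amino group of compound 1 is not the only substituent on this ring that moves the number beyond the scatter, which the earlier step alone could not show. The size of the new step stays open on one side, since compound 2 stands at a limit and not a number: the limit of > 150000 nM in this assay, at which 1 of the 3 values shown sits.

The fluoro does not make up the whole loss, for 4-fluorophenyl in place of 3-aminophenyl still gives a 4.2-fold higher number from compound 1 to compound 3 (0.62 log units; beyond the scatter), and that step changes both the group and its place on the ring, so it cannot separate the two effects.

Going by these compounds, what stays open is whether the gain belongs to fluoro alone or would also appear with a chlorine, a methoxy group or a hydroxyl at the same place. On these data alone, it is also open whether a fluoro and an amino group on one ring would add up, and how a 3-fluorophenyl or a 4-aminophenyl ring would compare.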